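Replacing the Carbamoyl of Compound 3 with Aminoethyl

This account rests on a few compounds, and the source may have more. Where it says the series, first, only, none or still open, it means among the compounds named here.

Of the compounds shown here, three on a shared core have been measured in a functional assay (Oryctolagus cuniculus) for antagonist activity at platelet-activating factor receptor (Cavia porcellus); on this read-out lower numbers stand for stronger inhibition and higher numbers for weaker inhibition. Compound 1 `CN(C)C(=O)n1cc(C(=O)c2ccn3c2CSC3c2cccnc2)c2ccc(Cl)cc21` gives 89 nM. Compound 2 `CCNC(=O)n1cc(C(=O)c2ccn3c2CSC3c2cccnc2)c2ccc(-c3ccc(F)cc3)cc21` gives 19 nM. Compound 3 `NC(=O)n1cc(C(=O)c2ccn3c2CSC3c2cccnc2)c2ccc(-c3ccc(F)cc3)cc21` gives 6 nM, the lowest of the three numbers, with compound 2 nearest and compound 1 furthest away. For the measured compounds named here, the single one-point step among them is a 3.2-fold lower number from compound 2 to compound 3 (0.50 log units; beyond the scatter), brought about by hydrogen in place of ethyl on an amide-type nitrogen. Compound 1 and compound 2 differ in two places, so their values show only a spread and no single cause.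

Compound 4 `NCCn1cc(C(=O)c2ccn3c2CSC3c2cccnc2)c2ccc(-c3ccc(F)cc3)cc21` differs from compound 3 in that (2-aminoethyl in place of carbamoyl on an aromatic nitrogen). Going by the values given here, no measured step exchanges the carbamoyl itself; the only step in hand altered merely what hangs on its nitrogen, and its modest size offers little guidance. With the carbonyl gone and the donor and acceptor counts kept, compound 4 is estimated to give 30 nM, expected between 5 nM and 200 nM. That estimate means an expected 5.0-fold higher number from compound 3 to compound 4 (0.70 log units; beyond the scatter), a loss that may still reach beyond the scatter.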

Compound 4, inhibition constant: 38 nM
For compound 4 the middle estimate is 1.3-fold (0.10 log units) below the measured one; the measured number falls inside the stated range.
By their numbers in this assay, from the lowest: compound 3; then compounds 2 and 4 (each within the scatter of the next); then compound 1.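

The earlier compounds shown here varied only what hangs on the carbamoyl nitrogen, whereas here the carbamoyl itself is exchanged on the aromatic nitrogen. In this assay, 2-aminoethyl in place of carbamoyl costs more than the ethyl group did (a 6.3-fold higher number from compound 3 to compound 4 (0.80 log units; beyond the scatter)), so the unsubstituted carbamoyl keeps a clear lead over this chain. Set against ethylcarbamoyl, the same chain cannot be told apart (a 2.0-fold higher number from compound 2 to compound 4 (0.30 log units; within the scatter)), which shows that a group without the carbonyl can match a substituted carbamoyl here, though nothing at hand explains either step.

The compounds shown do not separate the terminal amine from the ethyl chain that carries it. They also leave open how a 2-hydroxyethyl group, a longer aminoalkyl chain or a carboxylic acid would read on this aromatic nitrogen.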